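This account rests on a few compounds, and the source may have more. Where it says the series, first, only, none or still open, it means among the compounds named here.

Compound 2 `CCCn1c(=O)c2nc(C(C)(C)CCC)[nH]c2n(CCC)c1=O` gives 25 nM in an assay on cell membranes for binding affinity to adenosine receptor A1 (Cavia porcellus), read by radioligand binding (a lower number here means a stronger inhibitor, a higher number a weaker inhibitor), the lowest of the two numbers shown; compound 1 `CCCn1c(=O)c2nc(CC(C)(C)C)[nH]c2n(CCC)c1=O` gives 49 nM, and since a 2.0-fold lower number from compound 1 to compound 2 (0.29 log units; within the scatter), the two cannot be told apart. Compound 3 `CCCn1c(=O)c2nc([C@H]3CC4C=CC3C4)[nH]c2n(CCC)c1=O` differs from compound 2 by a group of 7 heavy atoms (7 carbon; 2 five-membered non-aromatic rings of carbon only) in place of a group of 6 heavy atoms (6 carbon; no ring), on an aromatic carbon. Going by the values given here, the single measured step, from a chain to a longer chain, bears on this change only loosely and itself stayed within the scatter, so no step beyond the scatter is expected here; the estimated step is no change at the digits printed from compound 2 to compound 3 (within the scatter). Compound 3 is therefore expected to give 25 nM, with a range from 8 nM to 80 nM.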

Compound 3, inhibition constant: 3.4 nM
For compound 3 the middle estimate is 7.4-fold (0.87 log units) above the measured one, and the stated range ends above it.
By their numbers in this assay, from the lowest: compound 3; then compounds 2 and 1 (each within the scatter of the next).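

In this assay the group with two five-membered non-aromatic rings gives a 7.4-fold lower number from compound 2 to compound 3 (0.87 log units; beyond the scatter) and a 14-fold lower number from compound 1 to compound 3 (1.16 log units; beyond the scatter), so this aromatic carbon responds to the substituent in a way that the two open-chain groups of compound 1 and compound 2 did not show. The rings, the double bond and the defined stereocentre enter together, so the step cannot be assigned to any one of them. No measurement here explains the step. Open, as far as these compounds go, is whether a cyclopentyl group, with a single ring and no double bond, keeps this value.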